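A Small Aryl Swap Where Both Anchors Sit at a Limit

A few compounds are considered here, and "the series" means these few. Any claim that something is new, unique, unknown or untested is made for them only; others in the source may bear on it.

Compound 1 `Fc1ccc2nc(-c3ccccc3)nc(Nc3ccccc3)c2c1` and compound 2 `Fc1cccc(-c2nc(Nc3cccc(Br)c3)c3cc(F)ccc3n2)c1` were each tested in a functional assay on COLO 205 cells (Homo sapiens) for cytotoxicity, read by MTT assay, with a stated time of 48 h; on this read-out lower numbers stand for stronger inhibition and higher numbers for weaker inhibition. Compound 1 gives > 50000 nM, which is a limit of the assay and not a number. Compound 2 gives > 50000 nM, likewise a limit. Both results thus stand at the limit of > 50000 nM in this assay, at which 2 of the 2 values shown sit. Compound 3 `Cc1ccccc1Nc1nc(-c2cccc(F)c2)nc2ccc(F)cc12` differs from compound 2 by 2-methylphenyl in place of 3-bromophenyl on a nitrogen on an aromatic ring. For the measured compounds named here, with no measured step available for comparison, the expected change from compound 2 to compound 3 is a step that the limit leaves unreadable from compound 2 to compound 3, nothing beyond the usual scatter. Compound 3 is therefore expected to give about 60000 nM in this assay, within a range of 20000 nM to 200000 nM.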

Compound 3, half-maximal inhibitory concentration: > 50000 nM
Compound 3 was reported as a limit (the forecaster's own chance of this, stated with the estimate: 80%); the middle value does not contradict the limit.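

For the compounds shown here, compound 2 and compound 3 both sit at a limit in this assay, so no step between them can be read: the limit of > 50000 nM in this assay, at which 3 of the 3 values shown sit. The compounds shown leave open which change to the shared core, if any, would give a measurable value.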